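The compounds below may be only part of what the source reports. "The series", "measured", "known", "first", "only" and "open" are said of these compounds alone.

Three close relatives of one shared core have been tested in a functional assay on KM12 cells (Homo sapiens) for antiproliferative activity; a lower number here means a stronger inhibitor of growth, a higher number a weaker inhibitor of growth. Compound 1 `COc1ccc(-c2nc3ccccc3s2)cc1OC` gives 74200 nM. Compound 2 `COc1ccc(-c2nc3cc(F)ccc3s2)cc1O`, which carries a fluorine and a hydroxy group, gives 18400 nM. Compound 3 `COc1cc(-c2nc3cc(F)ccc3s2)ccc1O` has its hydroxy and methoxy groups arranged differently from the way they stand in compound 2; in this assay compound 3 gives 47300 nM. Among the three numbers compound 3 holds the second highest; its gap to compound 1 lies within the usual scatter of repeated measurements, so no order can be read between those two, whereas compound 2 sits clearly lower, beyond the scatter.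

Compound 4 `COc1ccc(-c2nc3cc(F)ccc3s2)cc1OC` has not yet been measured. It differs from compound 3 in one place: methyl in place of hydrogen on an oxygen on an aromatic ring. For the measured compounds named here, no measured pair shows exactly this change, so its effect is not known from the data at hand. Going by the values given here, compound 1, the one measured compound that also carries two methoxy groups, gives 74200 nM, a number close to that of compound 3. On that basis the step is expected to be small, a 1.3-fold higher number from compound 3 to compound 4 (0.10 log units; within the scatter), and in neither direction beyond the scatter. Compound 4 is therefore estimated at 60000 nM, with a likely range from 25000 nM to 150000 nM.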

Compound 4, concentration for 50% growth inhibition: 290 nM
The estimate for compound 4 lay 210-fold (2.32 log units) above the measured number; the whole stated range lies above it.
By their numbers in this assay, from the lowest: compound 4; then compound 2; then compounds 3 and 1 (each within the scatter of the next).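

In this assay, replacing hydrogen with methyl on an oxygen on an aromatic ring is a large change whichever hydroxy arrangement it starts from, giving a 160-fold lower number from compound 3 to compound 4 (2.21 log units; beyond the scatter) and a 63-fold lower number from compound 2 to compound 4 (1.80 log units; beyond the scatter), so a free hydroxy group in either arrangement goes with far weaker growth inhibition than a second methoxy group on this fluorinated core. The methoxy groups alone do not account for this, since fluoro in place of hydrogen on an aromatic carbon gives a 260-fold lower number from compound 1 to compound 4 (2.41 log units; beyond the scatter); among these compounds, strong inhibition appears only where the fluoro and both methoxy groups occur together, and each of the other three compounds lacks one of these features. The data shown offer no measurement that explains why these two changes matter so much together.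

The compounds shown leave open whether methyl is special on that oxygen or whether an ethyl group or a longer chain would serve as well, and whether chlorine could take the place of the fluoro. They also leave open how a hydroxy group behaves on the core without any fluoro, so the size of the hydroxy-to-methoxy step may hold only in the presence of the fluoro.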